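Piperidine amide series: chain substituent change at the saturated ring

The source may hold more compounds than are shown below. What is called first, only, known or untested is meant among the compounds shown, and "the series" means these compounds.

Measured compounds in a functional assay on LNCaP cells (Homo sapiens) for antiproliferative activity; a lower number here means a stronger inhibitor, a higher number a weaker inhibitor:
compound 1 `Cn1ncc(Cl)c1-c1cc(C(=O)N[C@@H]2CN[C@H](CCCO)C[C@H]2c2ccc(Cl)c(Cl)c2)oc1Cl`: 210 nM
compound 2 `CC(=O)NCC[C@@H]1C[C@@H](c2ccc(F)c(F)c2)[C@H](NC(=O)c2cc(-c3c(Cl)cnn3C)c(Cl)o2)CN1`: 130 nM

Compound 1 gives the highest of the two numbers in this assay, and the gap to compound 2 lies within the scatter; the two read as equivalent. Compound 3 `Cn1ncc(Cl)c1-c1cc(C(=O)N[C@@H]2CN[C@H](CCN3CCCC3)C[C@H]2c2ccc(Cl)c(Cl)c2)oc1Cl` has not been measured. It differs from compound 1 as pyrrolidin-1-yl in place of hydroxymethyl on a saturated chain carbon, two bonds along the chain from a saturated ring carbon. Among the measured compounds shown here, no step between measured compounds covers this change, so the expectation rests on the values alone. The step is expected to be small, possibly toward a lower number, estimated as a 1.4-fold lower number from compound 1 to compound 3 (0.15 log units; within the scatter). Compound 3 is expected to give about 150 nM, in the range 50 nM to 500 nM.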

Compound 3, half-maximal inhibitory concentration: 1920 nM
Estimate against measurement, compound 3: 13-fold (1.11 log units) below; measured number outside the range, above it.
By their numbers in this assay, from the lowest: compounds 2 and 1 (each within the scatter of the next); then compound 3.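

In this assay, the end of the chain on the saturated ring is not a silent site: pyrrolidin-1-yl in place of hydroxymethyl gives a 9.1-fold higher number from compound 1 to compound 3 (0.96 log units; beyond the scatter) on an otherwise unchanged core. Among the compounds shown here, this is the first single-place step, and it lies beyond the scatter, so this position responds to the group at the chain end. Nothing on hand explains the step. On these data alone, whether the whole pyrrolidine ring matters or only its amine nitrogen stays open. A dimethylamino end group on the same chain, or a carboxylic acid there, would extend the comparison with compound 1.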